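Replacing vinylcarbonyl with methylsulfonyl on a shared core

The compounds below may be only part of what the source reports. "The series", "measured", "known", "first", "only" and "open" are said of these compounds alone.

Three measured compounds differ only in the group on a carbonyl carbon: compound 1 `CC(=O)Nc1ccc(-c2cn([C@@H]3CN[C@H](C(=O)Nc4ccc(Cl)c(C(F)(F)F)c4)C3)nn2)cn1`, compound 2 `CC(C)(C)C(=O)Nc1ccc(-c2cn([C@@H]3CN[C@H](C(=O)Nc4ccc(Cl)c(C(F)(F)F)c4)C3)nn2)cn1` and compound 3 `C=CC(=O)Nc1ccc(-c2cn([C@@H]3CN[C@H](C(=O)Nc4ccc(Cl)c(C(F)(F)F)c4)C3)nn2)cn1`. In a functional assay on K562 cells (Homo sapiens) for inhibition, read by MTT assay, with a stated time of 48 h (on this read-out higher numbers stand for weaker inhibition and lower numbers for stronger inhibition), compound 1 gives 8980 nM, compound 2 gives 43800 nM, and compound 3 gives 3860 nM, the lowest of the three numbers. Compound 4 `CS(=O)(=O)Nc1ccc(-c2cn([C@@H]3CN[C@H](C(=O)Nc4ccc(Cl)c(C(F)(F)F)c4)C3)nn2)cn1` carries methylsulfonyl in place of vinylcarbonyl on a nitrogen on an aromatic ring. Among the compounds with values here, no measured step makes this exact swap. The closest guides are a 2.3-fold lower number from compound 1 to compound 3 (0.37 log units; beyond the scatter), which is modest, and an 11-fold lower number from compound 2 to compound 3 (1.05 log units; beyond the scatter), which is large. Since compound 3 already sits lowest at 3860 nM, a modest rise in this assay is expected, namely a 2.3-fold higher number from compound 3 to compound 4 (0.37 log units; beyond the scatter). Compound 4 is estimated at 9000 nM, within an expected range of 3000 nM to 30000 nM.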

Compound 4, half-maximal inhibitory concentration: 5060 nM
Compound 4: middle estimate off by 1.8-fold (0.25 log units), on the high side; the measured number falls inside the stated range.
By their numbers in this assay, from the lowest: compounds 3, 4 and 1 (each within the scatter of the next, the first and the last beyond it); then compound 2.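

In this assay, methylsulfonyl in place of vinylcarbonyl on this nitrogen gives a 1.3-fold higher number from compound 3 to compound 4 (0.12 log units; within the scatter), and in place of acetyl it gives a 1.8-fold lower number from compound 1 to compound 4 (0.25 log units; within the scatter), so here a sulfonyl group reads the same as either of these two carbonyl groups. In place of (tert-butyl)carbonyl it gives an 8.7-fold lower number from compound 2 to compound 4 (0.94 log units; beyond the scatter), which leaves compound 2 as the only one of the four set clearly apart. No measurement shown explains these numbers. Open, on these data alone, is how a longer chain such as ethylsulfonyl, or a phenylsulfonyl group, would read at this nitrogen in this assay.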